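A few compounds are considered here, and "the series" means these few. Any claim that something is new, unique, unknown or untested is made for them only; others in the source may bear on it.

Measured in a functional assay on SK-BR-3 cells (Homo sapiens) for antiproliferative activity, read by MTT assay, with a stated time of 72 h (a lower number here means a stronger inhibitor, a higher number a weaker inhibitor), each value below being a limit of the assay and not a number:

compound 1 `C#CCOC(=O)C[C@@H]1C(C(=O)OC)=CO[C@@H](O[C@@H]2O[C@H](COC(C)=O)[C@@H](OC(C)=O)[C@H](OC(C)=O)[C@H]2OC(C)=O)/C1=C/C`: > 15000 nM
compound 2 `C/C=C1/[C@H](O[C@@H]2O[C@H](COC(C)=O)[C@@H](OC(C)=O)[C@H](OC(C)=O)[C@H]2OC(C)=O)OC=C(C(=O)OC)[C@H]1CC(=O)OCCC(C)C`: > 15000 nM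
compound 3 `C/C=C1/[C@H](O[C@@H]2O[C@H](COC(C)=O)[C@@H](OC(C)=O)[C@H](OC(C)=O)[C@H]2OC(C)=O)OC=C(C(=O)O)[C@H]1CC(=O)O`: > 20000 nM

Compound 2 has no number to stand on and sits at the limit of > 15000 nM in this assay, at which 2 of the 3 values shown sit, shared with compound 1. Compound 3 sits at the limit of > 20000 nM in this assay, at which 1 of the 3 values shown sits. For the measured compounds named here, no measured compound in this set therefore gives a number.

Compound 4 `C/C=C1/[C@H](O[C@@H]2O[C@H](COC(C)=O)[C@@H](OC(C)=O)[C@H](OC(C)=O)[C@H]2OC(C)=O)OC=C(C(=O)OC)[C@H]1CC(=O)OCCC` differs from compound 2 by methyl in place of isopropyl on a saturated chain carbon, two bonds along the chain from an oxygen next to a carbonyl group. In words, this is methyl in place of isopropyl on a saturated chain carbon, two bonds along the chain from an oxygen next to a carbonyl group. The same difference can be read as isopentyl to propyl.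

Going by the values given here, only one measured step touches this chain, namely a step that the two limits leave unreadable from compound 1 to compound 2. It offers no size to carry over, but it shows no number emerging when that ester chain is exchanged. No change beyond the scatter is therefore expected in this assay, and compound 4 will most likely be reported as a limit too.

The expected change is a step that the limit leaves unreadable from compound 2 to compound 4.

For compound 4 the estimate is 20000 nM, with an expected range of 12000 nM to 40000 nM.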

Compound 4, half-maximal inhibitory concentration: 6600 nM
Estimate against measurement, compound 4: 3.0-fold (0.48 log units) above; measured number below the stated range.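

In this assay, compound 4 is the only compound shown that gives a number rather than a limit, so the ester chain, changed on a saturated chain carbon, two bonds along the chain from an oxygen next to a carbonyl group, can move the read-out into a measurable range. Replacing isopentyl with propyl gives an at least 2.2-fold lower number from compound 2 to compound 4 (0.35 log units; beyond the scatter), and ethyl in place of ethynyl gives an at least 2.2-fold lower number from compound 1 to compound 4 (0.35 log units; beyond the scatter); both are minimum sizes. Compound 2 is a limit of the assay, as is compound 1, and the step joining those two cannot be read: the limit of > 15000 nM in this assay, at which 2 of the 4 values shown sit.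

The compounds shown leave open whether a butyl chain or a chain carrying an amine would give a lower number than compound 4. They also leave open how large either step really is.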